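A few compounds are considered here, and "the series" means these few. Any claim that something is new, unique, unknown or untested is made for them only; others in the source may bear on it.

Compound 2, `O=C(CCc1ccncc1-c1ccc2ccccc2c1)N1CCOCC1`: 45.5 nM
Compound 3, `O=C(O)/C=C/c1ccncc1-c1ccc2cc[nH]c2c1`: 2.4 nM
Compound 1, `CN1CCN(C(=O)/C=C/c2ccncc2-c2ccc(F)cc2)CC1`: 1210 nM

In an assay on a protein complex for inhibition of CDK8/Cyclin C (Homo sapiens), with a stated time of 1 h (on this read-out higher numbers stand for weaker inhibition and lower numbers for stronger inhibition), compound 2 sits second highest of the three numbers: compound 3 gives a number well below it, beyond the scatter, and compound 1 gives a number well above it, also beyond the scatter. Going by the values given here, no step between two measured compounds that differ in one place has been recorded. Compound 4, `COC(=O)CCc1ccncc1-c1ccc2ccccc2c1`, is not yet measured; it keeps the shared core of compound 2 and differs in a single place: methoxy in place of morpholin-4-yl on a carbonyl carbon. Among the compounds with values here, compounds 1 and 3 change several features at once, so this bare exchange of (morpholin-4-yl)carbonyl for methoxycarbonyl has no measured precedent here. Compound 4 is therefore expected to stay close to compound 2, with a modest step of a 1.5-fold higher number from compound 2 to compound 4 (0.19 log units; within the scatter) towards a weaker number, and an estimated 70 nM, within 14 nM to 350 nM.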

Compound 4, half-maximal inhibitory concentration: 259 nM
Compound 4: middle estimate off by 3.7-fold (0.57 log units), on the low side, and the stated range covers the measured number.
By their numbers in this assay, from the lowest: compound 3; then compound 2; then compound 4; then compound 1.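

In this assay, going by these compounds alone, the exchange of morpholin-4-yl for methoxy on a carbonyl carbon gives a 5.7-fold higher number from compound 2 to compound 4 (0.76 log units; beyond the scatter) and is the first step here in which only one place changes. It shows that this position is not indifferent to the group on the carbonyl, and within this pair the amide with the six-membered ring carries the lower number. No measurement on hand explains the step. Still open, from the compounds shown here alone, is how dimethylamino or piperidin-1-yl on the same carbonyl carbon would compare with morpholin-4-yl and methoxy. A longer chain to the carbonyl also remains untested among the compounds shown.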